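The source may hold more compounds than are shown below. What is called first, only, known or untested is meant among the compounds shown, and "the series" means these compounds.

Compound 1, `Cc1nc(-c2ccccc2)c(C(=O)N2CCN(c3ccccc3Cl)CC2)o1`: 124 nM
Compound 2, `COc1cccc(N2CCN(C(=O)c3oc(C)nc3-c3ccc(F)cc3)CC2)c1`: 112 nM
Compound 3, `COc1cccc(N2CCN(C(=O)c3oc(C)nc3-c3ccccc3)CC2)c1`: 34.8 nM

These three compounds share one core and were measured in a functional assay on HL-60 cells (Homo sapiens) for inhibition, read by MTT assay, with a stated time of 72 h; on this read-out lower numbers stand for stronger inhibition and higher numbers for weaker inhibition. Compound 3 gives the lowest number of the three: its nearest neighbour is compound 2, and the gap to compound 1 is slightly wider, both beyond the scatter. The step of a 3.2-fold lower number from compound 2 to compound 3 (0.51 log units; beyond the scatter) and the step of a 3.6-fold lower number from compound 1 to compound 3 (0.55 log units; beyond the scatter) are both modest and both run toward compound 3.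

Compound 4, `Cc1nc(-c2ccccc2)c(C(=O)N2CCN(c3ccccc3F)CC2)o1`, has not yet been measured. It differs from compound 3 in one place: 2-fluorophenyl in place of 3-methoxyphenyl on an amine nitrogen in a ring. The step that bears on this change is a 3.6-fold lower number from compound 1 to compound 3 (0.55 log units; beyond the scatter), in which a 2-chlorophenyl gave way to a 3-methoxyphenyl and the number fell. Compound 4 carries a 2-fluorophenyl at the same place, so the change from compound 3 runs the other way. Among the measured compounds shown here, no measured pair shows fluoro against chloro at this position, so how far compound 4 lands from compound 1 is not known from the numbers given.

Compound 4 is therefore expected to give a higher number than compound 3, a step of about a 2.9-fold higher number from compound 3 to compound 4 (0.46 log units; beyond the scatter). The estimate for compound 4 in this assay is 100 nM, with a range from 40 nM to 250 nM.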

Compound 4, half-maximal inhibitory concentration: 147 nM
For compound 4 the middle estimate is 1.5-fold (0.17 log units) below the measured one; the range from low to high includes it.
By their numbers in this assay, from the lowest: compound 3; then compounds 2, 1 and 4 (each within the scatter of the next).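

In this assay, among the compounds shown here, the step of a 1.2-fold higher number from compound 1 to compound 4 (0.07 log units; within the scatter) sets fluoro against chloro on this aromatic ring for the first time, and the two cannot be told apart. Together with the step of a 3.6-fold lower number from compound 1 to compound 3 (0.55 log units; beyond the scatter), the step of a 4.2-fold higher number from compound 3 to compound 4 (0.63 log units; beyond the scatter) shows that, with the shared core otherwise unchanged, 3-methoxyphenyl on the amine nitrogen gives a lower number than either 2-chlorophenyl or the 2-fluorophenyl of compound 4, so the earlier contrast was not confined to the chloro compound. Compound 2 goes against any reading that credits the 3-methoxyphenyl alone: it carries the same group, yet the step of a 3.2-fold lower number from compound 2 to compound 3 (0.51 log units; beyond the scatter) shows that the low number of compound 3 also depends on hydrogen in place of fluoro at the other changed place.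

Nothing available here accounts for the difference between these groups on the amine nitrogen. As far as these compounds go, what stays open is how a plain phenyl, or a phenyl carrying an amine, a carboxylic acid or a longer alkoxy chain, would compare at this place, and so whether the methoxy group itself matters.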